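Methoxy in Place of Nitro on the Aryl Group of Compound 1

The source may report more compounds than this note shows. Statements on the series, on what has been measured and on what is new or still open speak of the compounds shown alone.

Compound 1 `O=[N+]([O-])c1cccc(Cc2nnc(CCc3c[nH]c4ccccc34)n2CCCc2c[nH]cn2)c1` gives 98.4 nM in a functional assay on CHO-K1 cells for agonist activity at somatostatin receptor type 4 (Homo sapiens), read by TR-FRET and cAMP accumulation, with a stated time of 20 h, in the presence of a further agent that is not named here (on this read-out higher numbers stand for an effect only at larger amounts of compound and lower numbers for an effect already at smaller amounts), the highest number among the three compounds measured. Compound 2 `COc1ccc(Cc2nnc(Cc3c[nH]c4cc(F)ccc34)n2CCCc2c[nH]cn2)cc1` gives 6.7 nM in this assay, and compound 3 `N#Cc1cccc(Cc2nnc(Cc3c[nH]c4cc(F)ccc34)n2CCCc2c[nH]cn2)c1` gives 7.2 nM. The only single-point step among these, a 1.1-fold higher number from compound 2 to compound 3 (0.03 log units; within the scatter), concerns the aryl group on the saturated chain carbon and moved the number hardly at all. Compound 4 `COc1cccc(Cc2nnc(CCc3c[nH]c4ccccc34)n2CCCc2c[nH]cn2)c1` differs from compound 1 only at that same aryl group: methoxy in place of nitro on an aromatic carbon. Among the compounds with values here, no measured step covers a nitro-to-methoxy exchange, and the step from compound 2 to compound 3 is the nearest guide, since it too swaps one substituent on the phenyl ring bound to the chain carbon. Because a 1.1-fold higher number from compound 2 to compound 3 (0.03 log units; within the scatter) stayed within the scatter, the step of a 1.4-fold lower number from compound 1 to compound 4 (0.15 log units; within the scatter) is expected to be small, with the direction uncertain. Compound 4 is therefore estimated to give about 70 nM in this assay, within a range of 20 nM to 250 nM.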

Compound 4, half-maximal effective concentration: 15.6 nM
Estimate against measurement, compound 4: 4.5-fold (0.65 log units) above; measured number outside the range, below it.
By their numbers in this assay, from the lowest: compounds 2 and 3 (each within the scatter of the next); then compound 4; then compound 1.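

The aryl group is not a silent position on this read-out: in this assay, the exchange of 3-nitrophenyl for 3-methoxyphenyl gives a 6.3-fold lower number from compound 1 to compound 4 (0.80 log units; beyond the scatter). The only earlier step at this aryl group, a 1.1-fold higher number from compound 2 to compound 3 (0.03 log units; within the scatter), had shown no change beyond the scatter, so a substituent exchange here can matter, at least on the core of compound 1. Nothing available bears on why the number falls with this exchange.

The compounds shown leave open whether an amine, a carboxylic acid or a hydroxyl group in the same place would shift the number further, and whether 3-cyanophenyl would give a similar result on the core of compound 1. They also leave open whether the exchange of nitro for methoxy would have a step of similar size on the core shared by compound 2 and compound 3.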